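Aryl variation on the shared core: cytotoxicity notes

The compounds below may be only part of what the source reports. "The series", "measured", "known", "first", "only" and "open" are said of these compounds alone.

Measured so far:
compound 1 `Cc1cc(C)cc(-c2cc(C)c(Nc3ccnc(Nc4ccc(C#N)cc4)n3)c(C)c2)c1` — 4140 nM
compound 2 `Cc1cc(-c2cccc(F)c2)cc(C)c1Nc1ccnc(Nc2ccc(C#N)cc2)n1` — 4120 nM

In an ADME assay on MT4 cells (Homo sapiens) for cytotoxicity, read by MTT assay, with a stated time of 4 days (a higher number here means that more compound is tolerated, a lower number that less compound is tolerated), compound 1 gives 4140 nM and compound 2 gives 4120 nM. Of the two numbers shown, that of compound 2 is nominally the lowest, but the step of a 1.0-fold lower number from compound 1 to compound 2 (0.00 log units; within the scatter) is within the scatter, so the two compounds tolerate essentially the same concentration and neither can be called more or less tolerated than the other.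

Compound 3 `COc1ccccc1-c1cc(C)c(Nc2ccnc(Nc3ccc(C#N)cc3)n2)c(C)c1` is not yet measured. It differs from compound 2 in one place: 2-methoxyphenyl in place of 3-fluorophenyl on an aromatic carbon.

For the measured compounds named here, the only measured step, a 1.0-fold lower number from compound 1 to compound 2 (0.00 log units; within the scatter), concerns an exchange of the aryl group on the same aromatic carbon and produced no movement beyond the scatter. On that basis the exchange to 2-methoxyphenyl is also expected to leave the number essentially where compound 2 stands, with no step beyond the scatter expected in either direction.

Compound 3 is therefore estimated at 4200 nM in this assay, with a range of 2000 nM to 9000 nM. The expected step from compound 2 is a 1.0-fold higher number from compound 2 to compound 3 (0.01 log units; within the scatter).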

Compound 3, half-maximal cytotoxic concentration: 940 nM
The estimate for compound 3 lay 4.5-fold (0.65 log units) above the measured number; measured number below the stated range.
By their numbers in this assay, from the lowest: compound 3; then compounds 2 and 1 (each within the scatter of the next).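

In this assay, the aromatic carbon meta to two methyl groups turns out not to be indifferent to the aryl group it carries: 2-methoxyphenyl in place of 3-fluorophenyl gives a 4.4-fold lower number from compound 2 to compound 3 (0.64 log units; beyond the scatter), and 2-methoxyphenyl in place of 3,5-dimethylphenyl gives a 4.4-fold lower number from compound 1 to compound 3 (0.64 log units; beyond the scatter). The earlier exchange between 3,5-dimethylphenyl and 3-fluorophenyl stayed within the scatter, so the flat result there does not extend to every aryl group at this carbon, although the new steps are only modest in size. Nothing available here bears on why less compound is tolerated with 2-methoxyphenyl.

The compounds shown leave open whether the lower number follows the methoxy group itself or the place it occupies on the aryl ring, since 2-methoxyphenyl is the only group here that carries a methoxy group. A 3-methoxyphenyl or 2-fluorophenyl group at this carbon would separate those two readings, and an aminophenyl or carboxyphenyl group would show how far the number moves with a quite different substituent.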